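Cyclopropyl to phenyl on the amide carbonyl, inducible synthase

A few compounds are considered here, and "the series" means these few. Any claim that something is new, unique, unknown or untested is made for them only; others in the source may bear on it.

Of the compounds shown here, two have numbers so far. Compound 1 `COc1ccc(N)c(C(=O)CCNC(=O)c2ccccc2)c1` gives 10.9% in an assay for inhibition of Nitric oxide synthase, inducible (Homo sapiens), read by scintillation counting, with a stated time of 30 min, tested at 1 mM; a higher number here means more inhibition at the concentration tested (going by the name of the read-out), a lower number less inhibition. Compound 2 `Nc1ccc(Cl)cc1C(=O)CCNC(=O)C1CC1` gives 5.37% in this assay; the two numbers lie within the scatter of each other, so neither compound can be set apart from the other on these data. Both sit low at the tested concentration.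

Compound 3 `Nc1ccc(Cl)cc1C(=O)CCNC(=O)c1ccccc1` is not yet measured. It differs from compound 2 in one place: phenyl in place of cyclopropyl on a carbonyl carbon. For the measured compounds named here, no step between measured compounds covers this change on its own, though compound 1 already carries the phenyl amide together with a different substituent on the shared core and gives 10.9%.

For compound 3 the step from compound 2 is expected to be small, a number 2.6 percentage points higher from compound 2 to compound 3 (within the scatter), lying within the scatter. Compound 3 is therefore estimated at 8% in this assay, with a range from 0% to 20%.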

Compound 3, a percentage reported as inhibition, at one concentration (the size of the read-out at that concentration, not a potency): 26.6%
Compound 3: the middle estimate sits 18.6 percentage points below what was measured; the measured number lies above the stated range.
By their numbers in this assay, from the lowest: compounds 2 and 1 (each within the scatter of the next); then compound 3.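

On the chloro-bearing core, phenyl in place of cyclopropyl on a carbonyl carbon gives a number 21.2 percentage points higher from compound 2 to compound 3 (beyond the scatter) in this assay, so the group at this position changes the read-out, which compound 1 and compound 2 could not show as they differ in more than one place. With the phenyl amide held constant, chloro in place of methoxy on an aromatic carbon gives a number 15.7 percentage points higher from compound 1 to compound 3 (beyond the scatter), so the aromatic substituent also changes the read-out in this assay, and both steps are modest. Nothing at hand bears on the reason for either step.

The compounds shown do not tell whether the phenyl-for-cyclopropyl step holds on the methoxy-bearing core. They also leave open how a benzyl group or a longer alkyl chain on the amide carbonyl, or a fluoro or methyl group in place of chloro, would read.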